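The source may hold more compounds than are shown below. What is called first, only, known or untested is meant among the compounds shown, and "the series" means these compounds.

In an ADME assay on microsomes from liver (Mus musculus) for metabolic stability, read by LC-MS, using NADPH, with stated times of 10 min and 30 min, tested at 1 uM (on this read-out lower numbers stand for slow clearance and higher numbers for fast clearance), compound 1 (`COC(=O)C1=C(CN2CCCCC2)NC(c2nccs2)=NC1(C)c1ccc(F)cc1`) gives 88 mL/min/kg and compound 2 (`COC(=O)C1=C(CN2CCC(O)CC2)NC(c2nccs2)=NC1(C)c1ccc(F)cc1`) gives 81 mL/min/kg, two values within the scatter of each other. Compound 3 (`COC(=O)C1=C(CN2CCC(C(F)(F)F)C2)NC(c2nccs2)=NC1(C)c1ccc(F)cc1`) differs from compound 2 on a saturated chain carbon bound to a double-bonded ring carbon: 3-(trifluoromethyl)pyrrolidin-1-yl in place of 4-hydroxypiperidin-1-yl on a saturated chain carbon bound to a double-bonded ring carbon. For the measured compounds named here, the only measured step touching this group is a 1.1-fold lower number from compound 1 to compound 2 (0.04 log units; within the scatter), with hydroxy in place of hydrogen on a saturated ring carbon. Going by the values given here, no measured step changes the ring size or introduces trifluoromethyl, so the evidence is thin, and no step beyond the scatter is expected in this assay. The expected step is a 1.0-fold lower number from compound 2 to compound 3 (0.01 log units; within the scatter). For compound 3 the estimate is 80 mL/min/kg, with an expected range of 45 mL/min/kg to 120 mL/min/kg.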

Compound 3, clearance: 88 mL/min/kg
Compound 3: the middle estimate sits 1.1-fold (0.04 log units) below what was measured; the range from low to high includes it.
By their numbers in this assay, from the lowest: compounds 2, 1 and 3 (each within the scatter of the next).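

In this assay, the change at this place goes beyond a single ring substituent: swapping the whole ring for 3-(trifluoromethyl)pyrrolidin-1-yl gives a 1.1-fold higher number from compound 2 to compound 3 (0.04 log units; within the scatter) and also no change at the digits printed from compound 1 to compound 3 (within the scatter). Ring size, hydroxy and trifluoromethyl on a saturated chain carbon bound to a double-bonded ring carbon therefore leave compounds 1, 2 and 3 within the scatter of one another. Nothing at hand explains this.

From the compounds shown here alone, whether a morpholin-4-yl group or a piperidine carrying a carboxylic acid at this place would move the number beyond the scatter stays open. So does whether any change elsewhere on the shared core would.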